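The compounds below may be only part of what the source reports. "The series", "measured", "known", "first", "only" and "open" are said of these compounds alone.

Measured so far:
compound 1 `CC1=CC[C@H]2[C@@H]1CC=C(C)[C@@H](CC[C@H]1[C@]3(C)CC[C@H](O)C(C)(C)O[C@H]3CC[C@@]1(C)O)C2(C)C`; in a functional assay on MCF7 cells (Homo sapiens) for antiproliferative activity, read by MTT assay, with a stated time of 72 h (a lower number here means a stronger inhibitor, a higher number a weaker inhibitor), compound 1 gives > 50000 nM, which is a limit of the assay and not a number.
compound 2 `CC1=CC[C@H]2[C@H](CC[C@]2(C)O)C(C)(C)[C@@H]1CC[C@H]1[C@]2(C)CC[C@H](OCc3ccccc3)C(C)(C)O[C@H]2CC[C@@]1(C)O`; in this assay compound 2 gives > 50000 nM, again a limit of the assay rather than a number.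

Among the compounds with values here, compound 2 therefore stands on the limit, and the one other value shown, that of compound 1, is a limit too, so that both values sit at the same boundary (the limit of > 50000 nM in this assay, at which 2 of the 2 values shown sit). Within the data shown here, no step between two measured compounds is available, and nothing places compound 2 above or below any other compound in this assay.

Compound 3 `CC1=CC[C@H]2[C@H](CC[C@]2(C)O)C(C)(C)[C@@H]1CC[C@H]1[C@]2(C)CC[C@H](OC(=O)c3ccc([N+](=O)[O-])o3)C(C)(C)O[C@H]2CC[C@@]1(C)O` differs from compound 2 in a single place: (5-nitrofuran-2-yl)carbonyl in place of benzyl on an oxygen on a saturated carbon. Among the measured compounds shown here, nothing among the measured compounds shows what such a change does in this assay.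

The step from compound 2 to compound 3 is expected to be an at least 1.6-fold lower number from compound 2 to compound 3 (0.22 log units; that floor lies within the scatter), which is taken as small and not clearly beyond the scatter. Compound 3 is accordingly estimated at 30000 nM in this assay, with a range from 5000 nM to 100000 nM, and it is expected that the assay may again report only a limit.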

Compound 3, half-maximal inhibitory concentration: 21300 nM
Compound 3: middle estimate off by 1.4-fold (0.15 log units), on the high side; the range from low to high includes it.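

In this assay the oxygen on a saturated carbon of the shared core proves to be a place where the attached group can move the read-out: (5-nitrofuran-2-yl)carbonyl in place of benzyl gives an at least 2.3-fold lower number from compound 2 to compound 3 (0.37 log units; beyond the scatter). Compound 3, at 21300 nM, is the only compound shown with a measured number. The two earlier compounds gave only limits and could not show that any change here has a readable effect. Going by these compounds, the step is only a floor and its true size is unknown, because compound 2 stands at a limit of the assay: the limit of > 50000 nM in this assay, at which 2 of the 3 values shown sit.

The compounds shown leave open whether the step belongs to the nitro group, the furan ring or the carbonyl link, which all enter together here; a plain benzoyl group or an unsubstituted furan-2-carbonyl group on this oxygen would begin to separate them. On these data alone, it also remains open whether a group with an amine or a carboxylic acid at the end of a longer chain, attached on this same oxygen, would lower the number further.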